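The source may report more compounds than this note shows. Statements on the series, on what has been measured and on what is new or still open speak of the compounds shown alone.

Compound 1 `O=C(CN1CCC(c2ccc(F)cc2)(c2ccc(F)cc2)C1=O)N1CCN(Cc2cccc(C(F)(F)F)c2)CC1` was measured in a physicochemical assay for solubility, at pH 7; on this read-out lower numbers stand for lower solubility and higher numbers for higher solubility. In this assay compound 1 gives only a limit, < 25000 nM. Compound 2 `O=C(CN1CCCC(c2ccccc2)(c2ccccc2)C1=O)N1CCN(Cc2cccc(Cl)c2)CC1` likewise gives a limit in this assay, < 25000 nM. Compound 3 `O=C(CN1CCCC(c2ccccc2)(c2ccccc2)C1=O)N1CCN(Cc2ccc(Cl)cc2Cl)CC1` in this assay also reaches only a limit, < 25000 nM. The step that the two limits leave unreadable from compound 2 to compound 3 is therefore unreadable, since all three values sit at the limit of < 25000 nM in this assay, at which 3 of the 3 values shown sit. Compound 4 `O=C(CN1CCCC(c2ccccc2)(c2ccccc2)C1=O)N1CCN(Cc2cccc(C(F)(F)F)c2)CC1` differs from compound 3 by 3-(trifluoromethyl)phenyl in place of 2,4-dichlorophenyl on a saturated chain carbon bound to an amine nitrogen in a ring, that is, 2,4-dichlorobenzyl to 3-(trifluoromethyl)benzyl. Among the measured compounds shown here, no measured step reads out, so nothing points to a change beyond the scatter; compound 1 carries the same 3-(trifluoromethyl)benzyl group and sits at the limit. The step that the limit leaves unreadable from compound 3 to compound 4 is expected to be small. Compound 4 is estimated at 12000 nM, between 3000 nM and 40000 nM, most likely reported only as a limit.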

Compound 4, solubility: < 25000 nM
Compound 4: only a limit was reported; the forecaster's own chance of this, stated with the estimate: 75%; the middle value is on the limit's open side.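

Compound 4 also gives only a limit, so the steps to it from compound 2 and compound 3 cannot be read: the limit of < 25000 nM in this assay, at which 4 of the 4 values shown sit.

On these data alone, whether compound 2, compound 3 and compound 4 truly differ in this assay remains open.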